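A few compounds are considered here, and "the series" means these few. Any claim that something is new, unique, unknown or untested is made for them only; others in the source may bear on it.

Working notes on the series in a functional assay on HepG2 cells (Homo sapiens) for cytotoxicity, read by MTT assay, with a stated time of 48 h; on this read-out lower numbers stand for stronger inhibition and higher numbers for weaker inhibition. Compound 1 (`Cc1ccc(S(=O)(=O)N2N=C(c3cc4ccccc4oc3=O)CC2c2ccccc2)cc1`) is reported as "not active" (no number reported) and carries no number. Compound 2 (`CC(C)CNCC(=O)N1N=C(c2cc3ccccc3oc2=O)CC1c1ccccc1`) gives 9970 nM on the same read-out. Within the data shown here, that is the only number so far, so compound 2 cannot yet be ranked numerically against any other compound. Compound 3 (`CC1CCCN(CC(=O)N2N=C(c3cc4ccccc4oc3=O)CC2c2ccccc2)C1`) has not been measured. It carries 3-methylpiperidin-1-yl in place of isobutylamino on a saturated chain carbon bound to a carbonyl carbon. Among the measured compounds shown here, no measured step covers this kind of change, and the expectation can only start from compound 2 at 9970 nM and the structural change itself. The expected step is a 1.3-fold lower number from compound 2 to compound 3 (0.12 log units; within the scatter) and it is estimated to stay within the usual scatter, with no firm direction. Compound 3 is expected at 7500 nM (estimated range 2500 nM to 25000 nM).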

Compound 3, half-maximal inhibitory concentration: "not active" (no number reported)
Nothing numeric was reported for compound 3; the estimate stays without a comparison.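

In this assay, among these compounds, compound 3 gives "not active" (no number reported) and so offers no number to set against compound 2, and no step between them can be read. The compounds shown leave open how 3-methylpiperidin-1-yl in place of isobutylamino shifts the read-out. No evidence bears on this result.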